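The source may hold more compounds than are shown below. What is called first, only, known or untested is meant among the compounds shown, and "the series" means these compounds.

In a functional assay on A549 cells (Homo sapiens) for cytotoxicity, with a stated time of 48 h (a lower number here means a stronger inhibitor, a higher number a weaker inhibitor), compound 1 `C[S+]([O-])/C=C/c1cc(=O)c2ccccc2o1` gives 1900 nM, compound 2 `Cc1cccc2c(=O)cc(/C=C/[S+](C)[O-])oc12` gives 1700 nM and compound 3 `Cc1cccc2oc(/C=C/[S+](C)[O-])cc(=O)c12` gives 1300 nM. Compound 1 therefore stands level with both methyl compounds: a 1.1-fold lower number from compound 1 to compound 2 (0.05 log units; within the scatter) and a 1.5-fold lower number from compound 1 to compound 3 (0.16 log units; within the scatter) both lie within the scatter.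

Compound 4 `C[S+]([O-])/C=C/c1cc(=O)c2cc(F)ccc2o1` differs from compound 1 in one place: fluoro in place of hydrogen on an aromatic carbon. Going by the values given here, no measured step involves fluoro. The closest evidence is the pair of steps that put methyl in place of hydrogen on an aromatic carbon, so the expectation borrows from another group and remains weak. Neither compound 2 nor compound 3 shows a step beyond the scatter, so no step beyond the scatter is expected in this assay for the fluoro change, and no direction can be claimed. The expected step is small: a 1.2-fold lower number from compound 1 to compound 4 (0.07 log units; within the scatter). For compound 4 the estimated value is 1600 nM, with an expected range from 750 nM to 3300 nM.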

Compound 4, half-maximal inhibitory concentration: 2100 nM
Compound 4: middle estimate off by 1.3-fold (0.12 log units), on the low side, within the range that was stated.
By their numbers in this assay, from the lowest: compounds 3, 2, 1 and 4 (each within the scatter of the next).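

In this assay, fluoro in place of hydrogen on an aromatic carbon, meta to a fused ring and para to a fused ring, gives a 1.1-fold higher number from compound 1 to compound 4 (0.04 log units; within the scatter) and so leaves the number of the core of compound 1 within the scatter. The series now holds a reading for a group other than methyl on this six-membered aromatic ring of carbon only, and all three single changes on that ring, in compound 2, compound 3 and compound 4, stay within the scatter. Nothing available on these compounds bears on why this step is so small.

As far as these compounds go, whether an amine, a carboxylic acid or a longer chain at this position would give a step beyond the scatter remains open. Also open, from the compounds shown here alone, is how fluoro would read at the places that carry methyl in compound 2 and compound 3.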